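The compounds below may be only part of what the source reports. "The series", "measured", "known", "first", "only" and "open" are said of these compounds alone.

Compound 1 `N#Cc1cc(-c2nc(C(c3ccc(F)cc3)c3ccc(F)cc3)sc2CC(=O)O)ccc1F` gives 80% in an in vitro functional assay on HEK285-7 cells for antagonist activity at prostaglandin D2 receptor 2 (Homo sapiens), read by BRET and beta-arrestin recruitment; a higher number here means a larger maximal response, a lower number a smaller maximal response.
Compound 2 `O=C(O)Cc1sc(C(c2ccc(F)cc2)c2ccc(F)cc2)nc1-c1ccnc(N2CCCC2)c1` gives 80% in this assay.
Compound 3 `NS(=O)(=O)c1cccc(-c2nc(C(c3ccc(F)cc3)c3ccc(F)cc3)sc2CC(=O)O)c1` gives 55% in this assay.

Compound 3 stands lowest of the three numbers in this assay. The two measured steps that lead into it are a number 25 percentage points lower from compound 1 to compound 3 (beyond the scatter) and a number 25 percentage points lower from compound 2 to compound 3 (beyond the scatter), both beyond the scatter, while the step of no change at the digits printed from compound 1 to compound 2 (within the scatter) shows that the two other aryl groups on the shared core give the same maximal response within the scatter.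

Compound 4 `Cc1cc(-c2nc(C(c3ccc(F)cc3)c3ccc(F)cc3)sc2CC(=O)O)cnc1N` has not yet been measured in this assay. It differs from compound 3 by 6-amino-5-methylpyridin-3-yl in place of 3-sulfamoylphenyl on an aromatic carbon. Both steps that bear on this position, a number 25 percentage points lower from compound 1 to compound 3 (beyond the scatter) and a number 25 percentage points lower from compound 2 to compound 3 (beyond the scatter), show the 3-sulfamoylphenyl group giving the smallest response, so replacing it is expected to move the maximal response upward. Compound 2 carries a pyridine with a nitrogen substituent and gives 80%, which is taken as the nearer guide for the 6-amino-5-methylpyridin-3-yl group. Compound 4 is therefore expected to show a step of a number 20 percentage points higher from compound 3 to compound 4 (beyond the scatter) in this assay. The estimate for compound 4 is 75%, within a range from 60% to 90%.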

Compound 4, largest response reached (reported as efficacy), in percent of the reference or control that the assay uses: 80%
Compound 4: the middle estimate sits 5 percentage points below what was measured; the measured number falls inside the stated range.
By their numbers in this assay, from the lowest: compound 3; then compounds 1, 2 and 4 (each within the scatter of the next).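

In this assay the change at the aromatic carbon next to the ring nitrogen gives a number 25 percentage points higher from compound 3 to compound 4 (beyond the scatter) and so shows that a replacement for 3-sulfamoylphenyl with an amino group on a pyridine ring can restore the larger maximal response. The same group gives no change at the digits printed from compound 2 to compound 4 (within the scatter) and no change at the digits printed from compound 1 to compound 4 (within the scatter) as well, so 6-amino-5-methylpyridin-3-yl, 2-(pyrrolidin-1-yl)pyridin-4-yl and 3-cyano-4-fluorophenyl cannot be told apart in this read-out, with compound 3 alone standing apart among the four compounds. The 3-sulfamoylphenyl and 6-amino-5-methylpyridin-3-yl groups carry equal counts of hydrogen-bond donors and acceptors, so those counts do not separate compound 3 from compound 4.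

The compounds shown leave open whether the smaller response of compound 3 follows the sulfamoyl group itself or its place on the phenyl ring, which a methylsulfonyl group or a carboxamide on that ring could begin to test. No measurement given here accounts for the difference between compound 3 and compound 4.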